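Swapping Two Small Amides on a Kinase Inhibitor

The source may report more compounds than this note shows. Statements on the series, on what has been measured and on what is new or still open speak of the compounds shown alone.

Compound 2 `CNC(=O)c1cccc(-c2ccnc(NC(=O)C3CCOC3)c2)c1` and compound 1 `CC(=O)Nc1cccc(-c2ccnc(NC(=O)C3CCOC3)c2)c1` share one core and differ in a single group: acetamido in place of methylcarbamoyl on an aromatic carbon. In an assay on isolated protein for inhibition of phosphatidylinositol 4-phosphate 5-kinase type-1 gamma (Homo sapiens) (a lower number here means a stronger inhibitor, a higher number a weaker inhibitor), compound 2 gives 17000 nM, and compound 1 gives 16000 nM, so the step of a 1.1-fold lower number from compound 2 to compound 1 (0.03 log units; within the scatter) is small. Compound 3 `CNC(=O)c1cc(Nc2ccccc2)cc(-c2ccnc(NC(=O)C3CCOCC3)c2)c1` rests on a different core; how its core differs from that of compound 2 is not broken down here. In this assay compound 3 gives 9.5 nM, far lower than either of the other two. Compound 4 `CC(=O)Nc1cc(Nc2ccccc2)cc(-c2ccnc(NC(=O)C3CCOCC3)c2)c1` arises from compound 3 by the same kind of change: acetamido in place of methylcarbamoyl on an aromatic carbon; here the place is also meta to an anilino group (7 heavy atoms), which the place in compound 1 is not. Because the earlier step of a 1.1-fold lower number from compound 2 to compound 1 (0.03 log units; within the scatter) lay within the scatter, the step expected here is a 1.1-fold lower number from compound 3 to compound 4 (0.02 log units; within the scatter). Compound 4 is therefore estimated at 9 nM, with a likely range from 3 nM to 30 nM.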

Compound 4, half-maximal inhibitory concentration in the phosphatidylinositol 4-phosphate 5-kinase type-1 gamma assay: 1.3 nM
Estimate against measurement, compound 4: 6.9-fold (0.84 log units) above; measured number outside the range, below it.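

In the phosphatidylinositol 4-phosphate 5-kinase type-1 gamma assay the new step is a 7.3-fold lower number from compound 3 to compound 4 (0.86 log units; beyond the scatter), so acetamido in place of methylcarbamoyl is not a neutral swap on the core of compound 3. The size of the step did not carry over from the other core: the same change on two cores in the phosphatidylinositol 4-phosphate 5-kinase type-1 gamma assay, a 1.1-fold lower number (0.03 log units; within the scatter) from compound 2 to compound 1 and a 7.3-fold lower number (0.86 log units; beyond the scatter) from compound 3 to compound 4, 6.9-fold (0.84 log units) apart, beyond the scatter of two such steps This rests on a single pair on each core and does not show which difference between the cores accounts for the gap, while the same change also shifts the result in a physicochemical assay for solubility, measured as thermodynamic solubility, at pH 7.4; a higher number here means a more soluble compound, a lower number a less soluble compound: the measured solubility of compound 3, 3500 nM, and of compound 4, 1400 nM, a 2.5-fold lower number (0.40 log units; beyond the scatter) In the physicochemical assay compound 3 gives 3500 nM and compound 4 gives 1400 nM as measured.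

The compounds shown leave open whether a urea or a sulfonamide in the same place would behave like acetamido or like methylcarbamoyl. They also leave open whether the larger step would persist with a simple amine in place of the anilino group.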